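The compounds below may be only part of what the source reports. "The series", "measured", "known", "first", "only" and "open" are said of these compounds alone.

Measured so far in a functional assay on U-266 cells (Homo sapiens) for antiproliferative activity, read by MTT assay, with a stated time of 72 h; a higher number here means a weaker inhibitor, a lower number a stronger inhibitor:

compound 1, `N#C/C(=C\c1cccc(Br)n1)C(=O)NC(c1ccccc1)C1CC1`: 1300 nM
compound 2, `N#C/C(=C\c1cccc(Br)n1)C(=O)N[C@H](c1ccccc1)C1CC1`: "not determined" (no result reported)
compound 3, `CCC[C@H](NC(=O)/C(C#N)=C/c1c(Cl)cccc1[N+](=O)[O-])c1ccccc1`: "not determined" (no result reported)

Among the measured compounds shown here, compound 1 carries the only number in this assay; for compound 2 and compound 3 no result is reported, so no step between measured compounds can be stated. Compound 2 differs from compound 1 only in that (the fact that one of compounds 1 and 2 is drawn with a defined configuration and the other without, at the place where they differ), and no number exists to compare. Compound 1 therefore stands alone as the reference point for the series.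

The unmeasured compound 4, `N#C/C(=C\c1cccc(Br)n1)C(=O)NC(c1ccccc1)c1ccccc1`, differs from compound 1 by phenyl in place of cyclopropyl on a saturated chain carbon bound to an amide-type nitrogen and an aromatic carbon. For the measured compounds named here, the data give no measured step of this kind, so the expectation rests on compound 1 alone. A shift in this assay beyond the usual scatter is not expected in either direction; the step from compound 1 to compound 4 is estimated as a 1.2-fold higher number from compound 1 to compound 4 (0.06 log units; within the scatter). For compound 4 the expected value in this assay is 1500 nM, with a range from 500 nM to 4500 nM.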

Compound 4, half-maximal inhibitory concentration: 5800 nM
For compound 4 the middle estimate is 3.9-fold (0.59 log units) below the measured one; measured number above the stated range.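

In this assay, the saturated chain carbon bound to an amide-type nitrogen and an aromatic carbon proves sensitive to the group it carries: phenyl in place of cyclopropyl gives a 4.5-fold higher number from compound 1 to compound 4 (0.65 log units; beyond the scatter). Among the compounds shown here, this is the first step readable, and it shows that a second phenyl at this carbon goes with a weaker inhibitor than the three-membered ring, although it rests on a single pair. Nothing available bears on the reason for this step.

On these data alone, whether cyclobutyl, cyclohexyl, or a simple methyl or ethyl at this carbon would read closer to compound 1 or to compound 4 remains open, so ring size and aromatic character cannot be separated here. As far as these compounds go, the contribution of configuration at this carbon also remains open.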